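Shortening the ether chain of compound 3 to an allyl group

The source may hold more compounds than are shown below. What is called first, only, known or untested is meant among the compounds shown, and "the series" means these compounds.

Compound 3 `O=c1c(-c2ccc(O)cc2)coc2cc(OCCC3OCCCO3)ccc12` gives 57.6% in a functional assay on mitochondria (Cricetulus griseus) for inhibition of Monoamine oxidase (Homo sapiens), tested at 0.9 uM; on this read-out higher numbers stand for a stronger effect at the one concentration tested and lower numbers for a weaker effect. Among the three compounds measured it stands second highest: compound 2 `O=c1c(-c2ccc(O)cc2)coc2cc(OCCCCBr)ccc12` gives 55.3%, a number within the scatter of compound 3, while compound 1 `CCOc1ccc2c(=O)c(-c3ccc(O)cc3)coc2c1` gives 86.9%, which lies beyond the scatter above compound 3. Compound 4 `C=CCOc1ccc2c(=O)c(-c3ccc(O)cc3)coc2c1` has not yet been measured. It differs from compound 3 as follows: a group of 2 heavy atoms (2 carbon; no ring) in place of a group of 7 heavy atoms (5 carbon, 2 oxygen; one six-membered non-aromatic ring with 2 hetero atoms), on a saturated chain carbon bound to an oxygen on an aromatic ring The step of a number 29.3 percentage points lower from compound 1 to compound 3 (beyond the scatter) bears directly on this change, since the ring-containing group that enters there is the one that leaves here; the step of a number 31.6 percentage points lower from compound 1 to compound 2 (beyond the scatter) points the same way for another chain extension. Dropping the larger group is therefore expected to raise inhibition, with a number 22.4 percentage points higher from compound 3 to compound 4 (beyond the scatter). Compound 4 is estimated at 80%, with a range from 65% to 92%.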

Compound 4, a percentage reported as inhibition, at one concentration (the size of the read-out at that concentration, not a potency): 68.8%
Estimate against measurement, compound 4: 11.2 percentage points above; low and high end bracket the measured number.
By their numbers in this assay, from the lowest: compounds 2 and 3 (each within the scatter of the next); then compound 4; then compound 1.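

On a saturated chain carbon bound to an oxygen on an aromatic ring, vinyl gives a number 11.2 percentage points higher from compound 3 to compound 4 (beyond the scatter) and a number 13.5 percentage points higher from compound 2 to compound 4 (beyond the scatter) in this assay so part of what the larger groups lost comes back. Against methyl, vinyl gives a number 18.1 percentage points lower from compound 1 to compound 4 (beyond the scatter) so even two small groups are told apart here. Nothing measured on these compounds explains this order.

As far as these compounds go, whether a saturated propyl group would read nearer compound 1 or compound 4 stays open, as does the effect of an amine or a carboxylic acid at the end of a chain.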